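This account rests on a few compounds, and the source may have more. Where it says the series, first, only, none or still open, it means among the compounds named here.

In an ADME assay on MRC5 cells (Homo sapiens), read by MTT assay, with a stated time of 72 h (on this read-out higher numbers stand for weaker inhibition and lower numbers for stronger inhibition), compound 1 `C#Cc1cn([C@@H]2O[C@H](CO)[C@@H](O)[C@H]2O)c2ncnc(SC)c12` returns only a limit of the assay, > 100000 nM. Among the measured compounds shown here, compound 2 `Nc1nc2c(c(-c3ccoc3)cn2[C@@H]2O[C@H](CO)[C@@H](O)[C@H]2O)c(=O)[nH]1` gives 86100 nM, the only actual number available so far. Compound 3 `Nc1nc2c(c(-c3ccccc3)cn2[C@@H]2O[C@H](CO)[C@@H](O)[C@H]2O)c(=O)[nH]1` has phenyl in place of furan-3-yl on an aromatic carbon. For the measured compounds named here, no measured step bears on this swap, so in this assay a change within the usual scatter is expected, with no firm direction. The expected move is small, and the estimated step is a 1.2-fold lower number from compound 2 to compound 3 (0.09 log units; within the scatter). Compound 3 is expected at about 70000 nM, with an estimated range of 25000 nM to 100000 nM.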

Compound 3, half-maximal inhibitory concentration: > 100000 nM
Compound 3 was reported as a limit; the forecaster's own chance of this, stated with the estimate: 35%; at least 1.4-fold (0.15 log units) between middle value and limit.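

With phenyl in place of furan-3-yl on an aromatic carbon, this assay shows an at least 1.1-fold higher number from compound 2 to compound 3 (0.06 log units; that floor lies within the scatter). This first comparison at this position shows no move toward stronger inhibition with this swap. The value of compound 3 is a limit, so the step is only a floor and its true size cannot be read because of where that value sits: the limit of > 100000 nM in this assay, at which 2 of the 3 values shown sit.

Going by these compounds, it remains open whether an amine or a carboxylic acid on this aromatic carbon would give a number clear of that limit in this assay.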